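This account rests on a few compounds, and the source may have more. Where it says the series, first, only, none or still open, it means among the compounds named here.

So far two compounds sharing one core have been read in an ADME assay on HEp-2 cells (Homo sapiens) for cytotoxicity; on this read-out lower numbers stand for higher toxicity in this test and higher numbers for lower toxicity in this test. Compound 1 (`CC(C)CCn1c(Cn2c(=O)n(C(C)C)c3ccccc32)nc2ccc(CO)cc21`) gives 81600 nM, while compound 2 (`CC(C)CCn1c(Cn2c(=O)n(C(C)C)c3ccccc32)nc2ccc(CN(C)C)cc21`) gives 26700 nM, the lower of the two numbers. The next compound to be read is compound 3 (`CC(C)CCn1c(Cn2c(=O)n(C(C)C)c3ccccc32)nc2ccc(C(N)=O)cc21`). It differs from compound 2 as follows: carbamoyl in place of (dimethylamino)methyl on an aromatic carbon. In words, carbamoyl stands in place of (dimethylamino)methyl on an aromatic carbon. Among the measured compounds shown here, only one measured step bears on this change: putting dimethylamino in place of hydroxy gave a 3.1-fold lower number from compound 1 to compound 2 (0.49 log units; beyond the scatter), a modest move. Compound 3, like compound 1 at 81600 nM, carries no dimethylamino group, so a move back up of similar size is expected. For the measured compounds named here, this rests on a single step, and no measured compound here carries the carbamoyl group. The expected result in this assay is a 2.6-fold higher number from compound 2 to compound 3 (0.42 log units; beyond the scatter), a step toward the higher numbers. For compound 3 the estimate is 70000 nM, with an expected range from 30000 nM to 160000 nM.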

Compound 3, half-maximal cytotoxic concentration: 49900 nM
Compound 3: the middle estimate sits 1.4-fold (0.15 log units) above what was measured; low and high end bracket the measured number.
By their numbers in this assay, from the lowest: compounds 2, 3 and 1 (each within the scatter of the next, the first and the last beyond it).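

In this assay, carbamoyl in place of (dimethylamino)methyl gives a 1.9-fold higher number from compound 2 to compound 3 (0.27 log units; within the scatter), and carbamoyl in place of hydroxymethyl gives a 1.6-fold lower number from compound 1 to compound 3 (0.21 log units; within the scatter). Among the compounds shown here, compound 3 therefore cannot be separated from either compound 1 or compound 2, although those two stand apart beyond the scatter, so the one earlier step gains no clear third point in either direction. The result does show that this aromatic carbon can carry a group attached directly through a carbonyl, rather than through a saturated chain carbon, and still give a reading within the scatter of both earlier compounds, but no measurement here offers an explanation for this reading.

The compounds shown leave open whether a carboxylic acid, a primary aminomethyl group or a longer chain ending in dimethylamino on this aromatic carbon would widen the gap between compound 1 and compound 2 or fall inside it. They also leave open whether the order of compound 1 and compound 2 would hold with a group other than the isopropyl on the shared core.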